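This account rests on a few compounds, and the source may have more. Where it says the series, first, only, none or still open, it means among the compounds named here.

Measured in a functional assay on DU-145 cells (Homo sapiens) for cytotoxicity, read by trypan blue exclusion, with a stated time of 96 h; a lower number here means a stronger inhibitor, a higher number a weaker inhibitor:
- Compound 1 `COc1cc(OC)c(/C=C/S(=O)(=O)Cc2ccc(OC)c([N+](=O)[O-])c2)c(OC)c1`: 2500 nM
- Compound 2 `COc1cc(OC)c(/C=C/S(=O)(=O)Cc2ccc(OC)c(N)c2)c(OC)c1`: 4 nM
- Compound 3 `COC(=O)C(Nc1cc(CS(=O)(=O)/C=C/c2c(OC)cc(OC)cc2OC)ccc1OC)c1ccc(F)cc1`: 300 nM

Compound 3 holds the middle of these three numbers, lower than compound 1 and higher than compound 2. In compound 4 `COc1cc(OC)c(/C=C/S(=O)(=O)Cc2ccc(OC)c(NC(F)(F)C(=O)O)c2)c(OC)c1`, carboxy(difluoro)methyl takes the place of (4-fluorophenyl)(methoxycarbonyl)methyl on a nitrogen on an aromatic ring: carboxy(difluoro)methyl in place of (4-fluorophenyl)(methoxycarbonyl)methyl on a nitrogen on an aromatic ring.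

The most relevant measurement is the large step of a 75-fold higher number from compound 2 to compound 3 (1.88 log units; beyond the scatter), in which the group now leaving entered at that nitrogen. The large step of a 630-fold lower number from compound 1 to compound 2 (2.80 log units; beyond the scatter) shows that the number can also move strongly with a change at the same aromatic carbon. Neither step tests the entering group, so the direction is better supported than the size.

A moderate move to a lower number is expected in this assay, smaller than the rise seen when that group entered. The expected step is a 6.0-fold lower number from compound 3 to compound 4 (0.78 log units; beyond the scatter). For compound 4 the estimate is 50 nM, with an expected range from 8 nM to 400 nM.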

Compound 4, half-maximal inhibitory concentration: 150 nM
Beside the measured number, compound 4's estimate is 3.0-fold (0.48 log units) below it, and the stated range covers the measured number.
By their numbers in this assay, from the lowest: compound 2; then compounds 4 and 3 (each within the scatter of the next); then compound 1.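

In this assay the nitrogen on an aromatic ring carried a very different second substituent with no real separation from the first, as a 2.0-fold lower number from compound 3 to compound 4 (0.30 log units; within the scatter) shows, although carboxy(difluoro)methyl has 6 heavy atoms and no ring while the group leaving has 12 heavy atoms and one six-membered aromatic ring. Compound 4 also stays well apart from both the free amine and the nitro compound, with a 38-fold higher number from compound 2 to compound 4 (1.57 log units; beyond the scatter) on one side and a 17-fold lower number from compound 1 to compound 4 (1.22 log units; beyond the scatter) on the other. Nothing measured here explains why these substituents on the nitrogen separate compound 3 and compound 4 from compound 2.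

The compounds shown leave open whether a small group such as methyl or acetyl on this nitrogen would stay close to compound 2 or sit with compound 3 and compound 4. They also leave open how much of the number of compound 4 belongs to the carboxylic acid and how much to the two fluorines, which its methyl ester or an unfluorinated carboxymethyl group could separate.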